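Adding a Second Chloro to the Longer-Chain Core

The source may report more compounds than this note shows. Statements on the series, on what has been measured and on what is new or still open speak of the compounds shown alone.

The measured compounds:
Compound 1, `CCCCC(CCO)n1cnc2c(Cl)ncnc21`, gives in a functional assay on SW480 cells (Homo sapiens) for antiproliferative activity, read by MTT assay, with a stated time of 48 h (on this read-out higher numbers stand for weaker inhibition and lower numbers for stronger inhibition), a value of > 50000 nM, which is a limit of the assay and not a number.
Compound 2, `CCCCC(CCO)n1cnc2c(Cl)nc(Cl)nc21`, gives in this assay 30900 nM.
Compound 3, `CCCCCCCC(CCO)n1cnc2c(Cl)ncnc21`, gives in this assay 3630 nM.

Compound 3 carries the lowest of the two numbers shown, and compound 2 stands nearest to it; what separates these two is told only by their values. Compound 3 differs from compound 1 in its core by propyl in place of hydrogen on a saturated chain carbon, five bonds along the chain from an aromatic nitrogen, and this change produced an at least 13-fold lower number from compound 1 to compound 3 (1.13 log units; beyond the scatter). Compound 2 differs from compound 1 by chloro in place of hydrogen on an aromatic carbon, which produced an at least 1.6-fold lower number from compound 1 to compound 2 (0.20 log units; that floor lies within the scatter); that floor rests on (the limit of > 50000 nM in this assay, at which 1 of the 3 values shown sits).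

Compound 4, `CCCCCCCC(CCO)n1cnc2c(Cl)nc(Cl)nc21`, has not yet been measured. It differs from compound 3 by chloro in place of hydrogen on an aromatic carbon, the same change that was made from compound 1 to compound 2, occurring twice among the compounds shown. Since the earlier step is known only as a floor through an at least 1.6-fold lower number from compound 1 to compound 2 (0.20 log units; that floor lies within the scatter), the step from compound 3 to compound 4 is expected to be a 1.7-fold lower number from compound 3 to compound 4 (0.22 log units; within the scatter), a modest lowering of the number. Compound 4 is therefore estimated to give about 2200 nM, most likely falling between 700 nM and 6000 nM.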

Compound 4, half-maximal inhibitory concentration: 13600 nM
The estimate for compound 4 lay 6.2-fold (0.79 log units) below the measured number; the whole stated range lies below it.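

In this assay the chloro change did not carry over from one core to the other: it gave a 3.7-fold higher number from compound 3 to compound 4 (0.57 log units; beyond the scatter), which runs against the earlier step, and the two differ: the same change on two cores in this assay, an at least 1.6-fold lower number (0.20 log units; that floor lies within the scatter) from compound 1 to compound 2 and a 3.7-fold higher number (0.57 log units; beyond the scatter) from compound 3 to compound 4, at least 6.0-fold (0.78 log units) apart, beyond the scatter of two such steps The propyl change kept its direction but not its size, giving a 2.3-fold lower number from compound 2 to compound 4 (0.36 log units; beyond the scatter), and this step also stands apart from its earlier counterpart: the same change on two cores in this assay, an at least 13-fold lower number (1.13 log units; beyond the scatter) from compound 1 to compound 3 and a 2.3-fold lower number (0.36 log units; beyond the scatter) from compound 2 to compound 4, at least 6.0-fold (0.78 log units) apart, beyond the scatter of two such steps Compound 1 gives > 50000 nM, a limit of the assay and not a number, so the earlier steps are known only as floors, and these four compounds show that the two changes do not act independently of each other without showing why: the limit of > 50000 nM in this assay, at which 1 of the 4 values shown sits.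

The compounds shown leave open how the chloro step behaves on a chain longer than that of compound 3, and whether the reversal seen with compound 4 would persist there. They also leave open whether an amine or a methoxy group on the aromatic carbon between two ring nitrogen atoms would follow the same pattern as chloro on these two cores.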